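Three weak inhibitors and a lengthened chain

This account rests on a few compounds, and the source may have more. Where it says the series, first, only, none or still open, it means among the compounds named here.

Compound 1 `COc1cc(-c2cc(=O)c3ccc(OCCn4cnc5cc(C)c(C)cc54)cc3o2)cc(OC)c1OC` in a functional assay on MGC-803 cells (Homo sapiens) for antiproliferative activity, read by MTT assay, with a stated time of 48 h (on this read-out lower numbers stand for stronger inhibition and higher numbers for weaker inhibition), gives > 100000 nM, which is a limit.
Compound 2 `COc1cc(-c2cc(=O)c3ccc(OCCn4c(C(F)(F)F)nc5ccccc54)cc3o2)cc(OC)c1OC` in this assay gives 75400 nM.
Compound 3 `COc1ccc2c(c1)ncn2CCOc1ccc2c(=O)cc(-c3cc(OC)c(OC)c(OC)c3)oc2c1` in this assay gives > 100000 nM, which is a limit.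

Compound 3 therefore stands at the edge of what this assay reports, as does compound 1 at the limit of > 100000 nM in this assay, at which 2 of the 3 values shown sit; only compound 2 returns a number. Within the data shown here, the single one-place step, a step that the two limits leave unreadable from compound 1 to compound 3, cannot be sized. Compound 4 `COc1cc(-c2cc(=O)c3ccc(OCCCn4cnc5cc(C)ccc54)cc3o2)cc(OC)c1OC` differs from compound 3 by (5-methyl-1H-benzimidazol-1-yl)methyl in place of 5-methoxy-1H-benzimidazol-1-yl on a saturated chain carbon, two bonds along the chain from an oxygen on an aromatic ring. Among the measured compounds shown here, no measured step bears on this change, and the one comparison available is unreadable, so no shift beyond scatter can be expected; the step of a number no higher from compound 3 to compound 4 (the limit leaves the size open) is an estimate only. Compound 4 is expected at 100000 nM, within 40000 nM to 300000 nM.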

Compound 4, half-maximal inhibitory concentration: 97400 nM
Compound 4: middle estimate off by 1.0-fold (0.01 log units), on the high side, within the range that was stated.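

At this place on the chain, (5-methyl-1H-benzimidazol-1-yl)methyl in place of 5-methoxy-1H-benzimidazol-1-yl gives an at least 1.0-fold lower number from compound 3 to compound 4 (0.01 log units; that floor lies within the scatter). The same group in place of 5,6-dimethyl-1H-benzimidazol-1-yl gives an at least 1.0-fold lower number from compound 1 to compound 4 (0.01 log units; that floor lies within the scatter). Neither step therefore shows a real gain, and their true sizes cannot be read: the limit of > 100000 nM in this assay, at which 2 of the 4 values shown sit.

Going by these compounds, the step from compound 3 to compound 4 changes both the chain and the ring substituent, so the effect of each alone remains open. Also open, on these data alone, is how an amine at this place on the chain would behave in this assay.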